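The source may report more compounds than this note shows. Statements on the series, on what has been measured and on what is new or still open speak of the compounds shown alone.

Compound 1 `COc1ccc(-c2cc(=O)c3cc(CCl)ccc3o2)cc1` gives 32.2% in a functional assay on the whole organism (strain Wistar albino) for inhibition, with Rattus norvegicus as the target, read by paw edema, with stated times of 30 min and 2 h, at a dose of 20 mg/kg by the oral route; a lower number here means less inhibition, a higher number more inhibition at the dose given (going by the name of the read-out). Compound 2 `COc1ccc(-c2cc(=O)c3cc(CN(C)C)ccc3o2)cc1` gives 36% in this assay, and compound 3 `NS(=O)(=O)c1ccc(NCc2ccc3oc(-c4ccccc4Cl)cc(=O)c3c2)cc1` gives 32.2% in this assay. Among the measured compounds shown here, the single measured step, a number 3.8 percentage points higher from compound 1 to compound 2 (within the scatter), lies within the scatter, so compound 2 stands together with compound 1 and compound 3 inside the usual spread of such measurements, with no separation beyond it. Compound 4 `COc1ccc(-c2cc(=O)c3cc(CN(C)C)ccc3o2)cc1OC` differs from compound 2 by methoxy in place of hydrogen on an aromatic carbon. For the measured compounds named here, no measured step involves methoxy in place of hydrogen on an aromatic carbon, so the data give no direction for this change. Compound 4 is therefore expected to give 36% in this assay, within 22% to 50%. The step of no change at the digits printed from compound 2 to compound 4 (within the scatter) is expected to stay within the scatter.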

Compound 4, a percentage reported as inhibition, in the whole organism at one dose (the size of the read-out at that dose, not a potency): 29.8%
For compound 4 the middle estimate is 6.2 percentage points above the measured one, and the stated range covers the measured number.
By their numbers in this assay, from the lowest: compounds 4, 1, 3 and 2 (each within the scatter of the next).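

Methoxy in place of hydrogen on an aromatic carbon, ortho to a methoxy group and meta to a large group, now has a measured step in this assay (a number 6.2 percentage points lower from compound 2 to compound 4 (within the scatter)). On the dimethylamino compounds, this added group therefore brings no separation beyond the usual spread. The data offer no explanation for this result. Still open, on these data alone, is whether a hydroxyl group or an amine at this place would give a step beyond the scatter. Also open, as far as these compounds go, is whether the added methoxy would behave alike with chloro in place of dimethylamino.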